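Series notes: pyrimidinyl oxy versus sulfanyl linker

The source may hold more compounds than are shown below. What is called first, only, known or untested is meant among the compounds shown, and "the series" means these compounds.

Measured compounds in a functional assay on MGC-803 cells (Homo sapiens) for cytotoxicity, read by MTT assay, with a stated time of 3 days; on this read-out higher numbers stand for weaker inhibition and lower numbers for stronger inhibition:
compound 1 `Cc1cc(C)nc(Oc2ccc(NC(=O)Nc3ccccc3)cc2)n1` — "not determined" (no result reported)
compound 2 `Cc1cc(C)nc(Oc2ccc(NC(=O)Nc3ccc(OC(F)(F)F)cc3)cc2)n1` — > 50000 nM

Compound 1 `Cc1cc(C)nc(Oc2ccc(NC(=O)Nc3ccccc3)cc2)n1` has no reported value in this assay. For compound 2 `Cc1cc(C)nc(Oc2ccc(NC(=O)Nc3ccc(OC(F)(F)F)cc3)cc2)n1` the result in this assay is only a limit, > 50000 nM, not a number. Compound 2 thus stands at the edge of what the assay resolves, the one entry with a limit where the other entry carries no number at all (the limit of > 50000 nM in this assay, at which 1 of the 2 values shown sits). Among the compounds with values here, no step between two measured compounds exists in the pair, so no size of effect for any change has been observed.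

Compound 3 `Cc1cc(C)nc(Sc2ccc(NC(=O)Nc3ccc(OC(F)(F)F)cc3)cc2)n1` is not yet measured. It differs from compound 2 by (4,6-dimethylpyrimidin-2-yl)sulfanyl in place of (4,6-dimethylpyrimidin-2-yl)oxy on an aromatic carbon, the new group sitting para to a large group. The expected step is an at least 1.1-fold lower number from compound 2 to compound 3 (0.04 log units; that floor lies within the scatter), nothing beyond the scatter. For compound 3 the estimated value in this assay is 45000 nM, within 12000 nM to 150000 nM, with a fair chance that again only a limit is returned.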

Compound 3, half-maximal inhibitory concentration: 13800 nM
The estimate for compound 3 lay 3.3-fold (0.51 log units) above the measured number, and the stated range covers the measured number.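

In this assay, this position, an aromatic carbon para to a large group, gives the first readable effect in the series: (4,6-dimethylpyrimidin-2-yl)sulfanyl in place of (4,6-dimethylpyrimidin-2-yl)oxy gives an at least 3.6-fold lower number from compound 2 to compound 3 (0.55 log units; beyond the scatter). The exchange of oxygen for sulfur in the linker is thus enough to move the series from a limit to a measured number, and it leaves the heavy-atom count unchanged. The step is only a floor, because compound 2 carries a limit and not a number: the limit of > 50000 nM in this assay, at which 1 of the 3 values shown sits.

Going by these compounds, the true size of the step stays open, as does whether it carries over to the unsubstituted terminal phenyl ring of compound 1. Also open, on these data alone, is how an amine or methylene linker at this position would compare with the sulfanyl linker of compound 3.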